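A Benzothiophene in Place of a Benzimidazole

This account rests on a few compounds, and the source may have more. Where it says the series, first, only, none or still open, it means among the compounds named here.

In a functional assay on MCF7 cells (Homo sapiens) for inhibition, read by MTT assay, with a stated time of 72 h (on this read-out higher numbers stand for weaker inhibition and lower numbers for stronger inhibition), compound 1 `Cc1cc(Nc2cc(-c3ccccc3)[nH]n2)n2nc(SCc3ccc(F)cc3)nc2n1` gives 4020 nM and compound 3 `Cc1cc(Nc2cc(-c3ccccc3)[nH]n2)n2nc(SCc3nc4ccccc4[nH]3)nc2n1` gives 2730 nM. The step between them, a 1.5-fold lower number from compound 1 to compound 3 (0.17 log units; within the scatter), places compound 3 level with compound 1 on these numbers. Compound 2 `C=CCSc1nc2nc(C)cc(Nc3cc(-c4ccccc4)[nH]n3)n2n1` reports only a limit, > 50000 nM. The two steps that involve this limit are both large: an at least 12-fold higher number from compound 1 to compound 2 (1.09 log units; beyond the scatter) and an at least 18-fold lower number from compound 2 to compound 3 (1.26 log units; beyond the scatter). Each of them exchanges vinyl for a group with an aromatic ring.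

Compound 4 `Cc1cc(Nc2cc(-c3ccccc3)[nH]n2)n2nc(SCc3csc4ccccc34)nc2n1` carries 1-benzothiophen-3-yl in place of 1H-benzimidazol-2-yl on a saturated chain carbon bound to a sulfur. Among the measured compounds shown here, the closest precedent is the exchange of 4-fluorophenyl for 1H-benzimidazol-2-yl at this place, which gave a 1.5-fold lower number from compound 1 to compound 3 (0.17 log units; within the scatter). For the measured compounds named here, the large steps concern vinyl only, so no change beyond the scatter is expected here, although no measured step tests this exact exchange. The expected step is a 1.1-fold higher number from compound 3 to compound 4 (0.04 log units; within the scatter). For compound 4 the estimated value is 3000 nM, with an expected range of 1000 nM to 10000 nM.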

Compound 4, half-maximal inhibitory concentration: 3470 nM
Compound 4: the middle estimate sits 1.2-fold (0.06 log units) below what was measured; the range from low to high includes it.
By their numbers in this assay, from the lowest: compounds 3, 4 and 1 (each within the scatter of the next). At a limit, above all of these: compound 2.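

With a 1.3-fold higher number from compound 3 to compound 4 (0.10 log units; within the scatter) in this assay, the exchange of 1H-benzimidazol-2-yl, with 1 hydrogen-bond donor, for 1-benzothiophen-3-yl, with 0 hydrogen-bond donors, stays within the scatter, so in this pair the value does not depend on that donor. The second two-ring group also reads level with the single ring of 4-fluorophenyl, with a 1.2-fold lower number from compound 1 to compound 4 (0.06 log units; within the scatter). Against vinyl the step is an at least 14-fold lower number from compound 2 to compound 4 (1.15 log units; beyond the scatter), so among these four compounds all three groups with an aromatic ring stand apart from vinyl, and compound 2 reports a limit, not a number: the limit of > 50000 nM in this assay, at which 1 of the 4 values shown sits.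

From the compounds shown here alone, it stays open whether a cyclohexyl group or a longer saturated chain at this place would read like the aromatic groups or like vinyl. Going by these compounds, it is also open how an amine or a carboxylic acid on the 1-benzothiophen-3-yl ring would read.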